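This account rests on a few compounds, and the source may have more. Where it says the series, first, only, none or still open, it means among the compounds named here.

In a functional assay on A549 cells (Homo sapiens) for antiproliferative activity, read by MTT assay, with a stated time of 48 h (on this read-out lower numbers stand for stronger inhibition and higher numbers for weaker inhibition), compound 1 (`Brc1ccc2[nH]c(-c3cn(-c4ccccc4)nc3-c3ccccc3)nc2c1`) gives 1810 nM and compound 2 (`Clc1ccc(-c2nn(-c3ccccc3)cc2-c2nc3ccccc3[nH]2)cc1`) gives 5960 nM, while compound 3 (`Clc1ccc(-c2nn(-c3ccccc3)cc2-c2nc3cc(Br)ccc3[nH]2)cc1`) gives 2170 nM on the same test. Compound 3 therefore stands level with compound 1 within the scatter, and its number is clearly lower than that of compound 2.

Compound 4 (`O=C(OCc1ccccc1)c1ccc2[nH]c(-c3cn(-c4ccccc4)nc3-c3ccc(Cl)cc3)nc2c1`) is made from compound 3 by one change, benzyloxycarbonyl in place of bromo on an aromatic carbon with benzyloxycarbonyl in place of bromo on an aromatic carbon. Two measured steps lead to compound 3. Adding chloro gave a 1.2-fold higher number from compound 1 to compound 3 (0.08 log units; within the scatter) but concerns a different group, so it says little here. Adding bromo gave a 2.7-fold lower number from compound 2 to compound 3 (0.44 log units; beyond the scatter) and matters more, since bromo is the group that now leaves. That step was modest, and it shows only what bromo does compared with hydrogen. Going by the values given here, no measured compound carries benzyloxycarbonyl, a much larger group, so neither the size nor the direction of the change is firmly known.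

In this assay the expected result is a slight drift toward a higher number, with no step beyond the scatter. The estimated change is a 1.4-fold higher number from compound 3 to compound 4 (0.14 log units; within the scatter) on this evidence. Compound 4 is expected at 3000 nM with an estimated range from 900 nM to 10000 nM when it is tested.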

Compound 4, half-maximal inhibitory concentration: 7730 nM
Compound 4: the middle estimate sits 2.6-fold (0.41 log units) below what was measured; the range from low to high includes it.
By their numbers in this assay, from the lowest: compounds 1 and 3 (each within the scatter of the next); then compounds 2 and 4 (each within the scatter of the next).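

In this assay, going by these compounds alone, benzyloxycarbonyl is the first group at this position that gives up what bromo had gained, with a 3.6-fold higher number from compound 3 to compound 4 (0.55 log units; beyond the scatter). Set against hydrogen, the same group shows a 1.3-fold higher number from compound 2 to compound 4 (0.11 log units; within the scatter), so on this chloro-bearing background it offers no measurable gain over the unsubstituted compound, whereas bromo does. The position is therefore not one where any added group brings the number down: the outcome depends on which group is placed there, and nothing available explains why these two groups differ.

On these data alone, only two substituents and hydrogen can be compared at this position, all with the chloro group present, so it remains open whether the same loss would appear on the core of compound 1, which lacks chloro. As far as these compounds go, it is also open whether a carboxylic acid, a methyl ester or a primary amide in the same place would track bromo, hydrogen or benzyloxycarbonyl, which would help separate the role of the carbonyl from that of the added aromatic ring.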